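The source may report more compounds than this note shows. Statements on the series, on what has been measured and on what is new or still open speak of the compounds shown alone.

Measured in a functional assay on MT4 cells (Homo sapiens), read by MTT assay; on this read-out lower numbers stand for higher toxicity in this test and higher numbers for lower toxicity in this test:
- compound 1 `C#C[C@]1(CO)O[C@@H](n2cnc3c(N)ncnc32)C[C@@H]1O`: 11700 nM
- compound 2 `C#C[C@]1(CO)O[C@@H](n2cnc3cncnc32)C[C@@H]1O`: > 380000 nM (a limit of the assay)

For the measured compounds named here, compound 1 holds the only exact number so far, as the entry for compound 2 is a limit. Compound 3 `C#C[C@]1(CO)O[C@@H](n2cnc3c(N)nc(N)nc32)C[C@@H]1O` differs from compound 1 by one change: amino in place of hydrogen on an aromatic carbon. Going by the values given here, only one measured step bears on this, and it was large: an at least 32-fold higher number from compound 1 to compound 2 (1.51 log units; beyond the scatter). That step removed an amino group from another carbon, so it is a weak guide to adding one here. In this assay, only a small step with no firm direction is expected. For compound 3 the expected value is 10000 nM, with an estimated range of 2500 nM to 50000 nM.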

Compound 3, half-maximal cytotoxic concentration: 820 nM
Compound 3: the middle estimate sits 12-fold (1.09 log units) above what was measured, outside the stated range (below it).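

The carbon between two ring nitrogen atoms is not a neutral place on the core: amino in place of hydrogen there gives a 14-fold lower number from compound 1 to compound 3 (1.15 log units; beyond the scatter) in this assay and so higher toxicity in this test. The earlier step concerned only an amino group on another carbon, and amino on either carbon now goes with a lower number. Compound 2 remains a limit, not a number: the limit of > 380000 nM in this assay, at which 1 of the 3 values shown sits.

From the compounds shown here alone, whether a hydroxyl, a chlorine or a methylamino group on this carbon would lower the number as well stays open.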